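The source may hold more compounds than are shown below. What is called first, only, known or untested is meant among the compounds shown, and "the series" means these compounds.

Compound 1 `CN(C)c1ncnc2c1c(-c1ccoc1)cn2[C@@H]1O[C@H](CO)[C@@H](O)[C@H]1O`: in a functional assay on HCT-116 cells (Homo sapiens), read by MTT assay, with a stated time of 72 h (on this read-out higher numbers stand for weaker inhibition and lower numbers for stronger inhibition), compound 1 gives > 20000 nM, a limit of the assay rather than a number.
Compound 2 `CN(C)c1ncnc2c1c(-c1cc3ccccc3o1)cn2[C@@H]1O[C@H](CO)[C@@H](O)[C@H]1O`: in this assay compound 2 gives > 20000 nM, again a limit.
Compound 3 `Nc1nc(N)c2c(-c3ccoc3)cn([C@@H]3O[C@H](CO)[C@@H](O)[C@H]3O)c2n1`: in this assay compound 3 gives > 20000 nM, also a limit.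

The change 1-benzofuran-2-yl in place of furan-3-yl on an aromatic carbon produced a step that the two limits leave unreadable from compound 1 to compound 2, since all three values sit at the limit of > 20000 nM in this assay, at which 3 of the 3 values shown sit. The difference between the core of compound 1 and the core of compound 3 is not broken down here. Compound 4 `Nc1nc(N)c2c(-c3cc4ccccc4o3)cn([C@@H]3O[C@H](CO)[C@@H](O)[C@H]3O)c2n1` carries the same change as compound 3, namely (1-benzofuran-2-yl in place of furan-3-yl on an aromatic carbon), at a place described in identical words. Compound 4 is expected to show a step that the limit leaves unreadable from compound 3 to compound 4, an expectation resting on compound 3 at > 20000 nM and on the unreadable step from compound 1 to compound 2. Compound 4 is therefore estimated at 30000 nM, most probably reported as a limit again.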

Compound 4, half-maximal inhibitory concentration: 14000 nM
For compound 4 the middle estimate is 2.1-fold (0.33 log units) above the measured one; low and high end bracket the measured number.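

In this assay, 1-benzofuran-2-yl in place of furan-3-yl gives an at least 1.4-fold lower number from compound 3 to compound 4 (0.15 log units; that floor lies within the scatter), so the true step may be larger, but its size is not fixed. Compound 3 gives > 20000 nM, which is a limit of the assay. For the compounds shown here, the same change cannot be read on the core of compound 1, so the data do not show that its effect carries from one core to the other, only that a number appears on one core and not on the other.

Still open, going by these compounds, is how the change would behave on a core where the furan-3-yl compound gives a measurable number. Also open, on these data alone, is how an amine, a carboxylic acid or a longer chain would fare on this aromatic carbon.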